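Vinyl in Place of Prop-1-yn-1-yl on Two Cores

The source may report more compounds than this note shows. Statements on the series, on what has been measured and on what is new or still open speak of the compounds shown alone.

Compound 2 `CC#Cc1nc2ccccc2s1` and compound 1 `C=Cc1nc2ccccc2s1` share one core and differ only by vinyl in place of prop-1-yn-1-yl on an aromatic carbon. In a functional assay on NCI-H522 cells (Homo sapiens) for cytotoxicity, with a stated time of 3 days (a lower number here means a stronger inhibitor, a higher number a weaker inhibitor), compound 2 gives only a limit, > 40000 nM. Compound 1 also gives only a limit in this assay, > 40000 nM. The step that the two limits leave unreadable from compound 2 to compound 1 therefore cannot be read, because both values sit at the limit of > 40000 nM in this assay, at which 3 of the 3 values shown sit.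

Compound 3 `CC#Cc1nc(C(=O)OCC)cs1` has a different core; how the two cores differ is not broken down here. In this assay compound 3 gives only a limit, > 40000 nM. Compound 4 `C=Cc1nc(C(=O)OCC)cs1` has not yet been measured and differs from compound 3 by vinyl in place of prop-1-yn-1-yl on an aromatic carbon. This is the same kind of change as from compound 2 to compound 1, though the surroundings differ: in the first pair the ring is part of a fused or bridged system of two rings, whereas here it is two ring bonds from the ring atom that bears a group of 5 heavy atoms.

The expected step that the limit leaves unreadable from compound 3 to compound 4 rests on compound 2 and compound 1 both sitting at the limit of > 40000 nM in this assay, at which 3 of the 3 values shown sit. Compound 4 is expected to give about 60000 nM, between 20000 nM and 200000 nM, most likely again reported only as a limit.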

Compound 4, half-maximal inhibitory concentration: > 40000 nM
Compound 4: no number, only a limit (the forecaster's own chance of this, stated with the estimate: 85%); the middle value does not contradict the limit.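

Compound 4 gives only a limit in this assay, > 40000 nM. No size can therefore be read for the change from compound 3 to compound 4, because both compounds sit at the same limit: the limit of > 40000 nM in this assay, at which 4 of the 4 values shown sit.

The compounds shown leave open how vinyl and prop-1-yn-1-yl compare on either core, as none of them gives an actual number.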